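The source may report more compounds than this note shows. Statements on the series, on what has been measured and on what is new or still open speak of the compounds shown alone.

The compounds measured so far, each with its value in an assay on isolated protein for displacement of a labelled ligand from metabotropic glutamate receptor 5 (Homo sapiens), with a stated time of 60 min, tested at 1 uM; on this read-out higher numbers stand for more inhibition at the one concentration tested (going by the name of the read-out) and lower numbers for less inhibition:

Compound 1, `Cc1ccc2ncc(S(=O)(=O)c3ccc(F)cc3)c(N3CCC(C)CC3)c2c1` — compound 1 gives 90%.
Compound 2, `CC1CCN(c2c(S(=O)(=O)c3ccc(Cl)c(Cl)c3)cnc3cc(F)ccc23)CC1` — compound 2 gives 94%.
Compound 3, `Cc1ccc2ncc(S(=O)(=O)c3cc(F)cc(F)c3)c(N3CCC(C)CC3)c2c1` — compound 3 gives 72%.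

Compound 2 is separated from compound 3 by a gap beyond the scatter, whereas compound 1 cannot be told apart from it on these numbers. Within the data shown here, the one single-point step among the measured compounds is a number 18 percentage points lower from compound 1 to compound 3 (beyond the scatter), a modest fall.

Compound 4, `CC1CCN(c2c(S(=O)(=O)c3cc(Cl)cc(Cl)c3)cnc3cc(F)ccc23)CC1`, has not yet been measured in this assay. It differs from compound 2 in one place: 3,5-dichlorophenyl in place of 3,4-dichlorophenyl on a sulfonyl sulfur.

The step from compound 1 to compound 3 bears on this change in part: there too a substituted phenyl on the sulfonyl sulfur went to a 3,5-disubstituted pattern, and the number fell beyond the scatter. Here, however, one of the two chlorines already sits in the 3-position of compound 2, so only part of that change recurs, and a smaller drop is expected. The expected step is a number 12 percentage points lower from compound 2 to compound 4 (beyond the scatter), downward but modest. For compound 4 the estimate in this assay is 82%, with a range from 62% to 96%.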

Compound 4, a percentage reported as inhibition, at one concentration (the size of the read-out at that concentration, not a potency): 87%
The estimate for compound 4 lay 5 percentage points below the measured number, within the range that was stated.
By their numbers in this assay, from the lowest: compound 3; then compounds 4, 1 and 2 (each within the scatter of the next).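

In this assay, 3,5-dichlorophenyl in place of 3,4-dichlorophenyl on the sulfonyl sulfur gives a number 7 percentage points lower from compound 2 to compound 4 (within the scatter), so moving one chlorine while keeping the same atoms produces no change that can be told from scatter on these numbers. Among these compounds, the only earlier step at this position, a number 18 percentage points lower from compound 1 to compound 3 (beyond the scatter), ended in a 3,5-difluorophenyl group, and compound 4 now shows that a 3,5-disubstituted phenyl on the sulfonyl sulfur does not always come with a fall beyond the scatter. Nothing shown here accounts for the difference between the two steps.

The two steps differ in the halogen, in the group they start from and in the shared core, so the compounds shown leave open which of these separates them. They also leave open whether a 3,5-dimethoxyphenyl or a pyridine ring on the sulfonyl sulfur would stay level with compound 2 or fall away as compound 3 does, and, with a single tested concentration, how the potencies of the compounds compare.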